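This account rests on a few compounds, and the source may have more. Where it says the series, first, only, none or still open, it means among the compounds named here.

Measured compounds in an assay on cells for displacement of a labelled ligand from adenosine receptor A1 (Homo sapiens), read by scintillation counting and radioligand binding, with a stated time of 60 min, tested at 10 uM; a higher number here means more inhibition at the concentration tested (going by the name of the read-out), a lower number less inhibition:

compound 1, `CN1CCN(c2nc(-c3ccc(Cl)c(Cl)c3)nc3c2ncn3C)CC1`, 65.2%
compound 2, `Clc1ccc(Cl)c(-c2nc(N3CCCCC3)c3nc[nH]c3n2)c1`, 1.4%
compound 3, `CN1CCN(c2nc(-c3cccc(Cl)c3)nc3c2ncn3C)CC1`, 45.7%

Compound 2 and compound 1 differ in more than one place; the difference between the two cores is not broken down here. What the values show is that compound 2 sits lowest of the three, beyond the scatter from both compound 3 and compound 1.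

Within the core of compound 1, the change hydrogen in place of chloro on an aromatic carbon gives a number 19.5 percentage points lower from compound 1 to compound 3 (beyond the scatter).

Compound 4, `Clc1cccc(-c2nc(N3CCCCC3)c3nc[nH]c3n2)c1`, is still to be measured in this assay. It arises from compound 2 by hydrogen in place of chloro on an aromatic carbon. This is the same kind of change as from compound 1 to compound 3, not the same: there the hydrogen entered ortho to a chloro group and para to a large group; here it enters ortho to a large group and para to a chloro group.

A step of similar direction is expected for compound 4, but far smaller, because compound 2 already gives 1.4%, leaving little room for a further drop. Compound 4 is therefore estimated at 1%, within -6% to 9%. The expected step is a number 0.4 percentage points lower from compound 2 to compound 4 (within the scatter).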

Compound 4, a percentage reported as inhibition, at one concentration (the size of the read-out at that concentration, not a potency): > 80%
Compound 4 ended at the assay's limit; the forecaster's own chance of this, stated with the estimate: 0%; at least 79 percentage points between middle value and limit.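

In this assay, hydrogen in place of chloro on an aromatic carbon gives a number at least 78.6 percentage points higher from compound 2 to compound 4 (beyond the scatter), so the change does not carry from the core of compound 1 to the core of compound 2, not even in direction: the same change on two cores in this assay, a number 19.5 percentage points lower (beyond the scatter) from compound 1 to compound 3 and a number at least 78.6 percentage points higher (beyond the scatter) from compound 2 to compound 4, at least 98.1 percentage points apart, beyond the scatter of two such steps

Compound 4 stands at > 80%, which is a limit of the assay and not a number: the limit of > 80% in this assay, at which 1 of the 4 values shown sits.

This does not show whether the core or the place of the change sets the step: from compound 2 the hydrogen enters ortho to a large group and para to a chloro group, from compound 1 it enters ortho to a chloro group and para to a large group, and the two cores differ in more than one place.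

The compounds shown leave open how the core of compound 1 responds to the same change at the place it has in compound 2. Also open, on these data alone, is how a fluoro or a methoxy group at that place on the core of compound 2 would compare with compound 4.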